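Ring Enlargement on a Metabolically Tested Series

The source may report more compounds than this note shows. Statements on the series, on what has been measured and on what is new or still open speak of the compounds shown alone.

- compound 1 `CCCN(Cc1ccc(OCCN2C(=O)CCC2=O)c(C)c1)C(CC(=O)O)c1ccc(Cl)cc1`: 85%
- compound 2 `CCN(Cc1ccc(OCCN2C(=O)CCC2=O)c(C)c1)C(CC(=O)O)c1ccc(Cl)cc1`: 100%
- compound 3 `Cc1cc(CN(CC2CCCC2)C(CC(=O)O)c2ccc(Cl)cc2)ccc1OCCN1C(=O)CCC1=O`: 65%

In an ADME assay on liver (Homo sapiens) for metabolic stability, read by LC-MS, using microsomes and NADPH (on this read-out lower numbers stand for a less stable compound and higher numbers for a more stable compound), compound 3 gives 65%, the lowest of the three numbers. Compound 4 `Cc1cc(CN(CC2CCCCC2)C(CC(=O)O)c2ccc(Cl)cc2)ccc1OCCN1C(=O)CCC1=O` carries cyclohexyl in place of cyclopentyl on a saturated chain carbon bound to an amine nitrogen.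

Among the measured compounds shown here, three measured steps bear on this change. Two of them end in cyclopentyl at that place: a number 20 percentage points lower from compound 1 to compound 3 (beyond the scatter) and a number 35 percentage points lower from compound 2 to compound 3 (beyond the scatter). The third is a number 15 percentage points higher from compound 1 to compound 2 (beyond the scatter). Across these three compounds the number falls as the group at that place grows, and none of them goes against this. For the measured compounds named here, no measured step exchanges one ring for another, however, and the present change is smaller than those measured. A small downward move is therefore expected, possibly not exceeding the usual scatter.

The expected change is a number 10 percentage points lower from compound 3 to compound 4 (within the scatter). For compound 4 the estimated value is 55%, with an expected range from 35% to 72%.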

Compound 4, percent of the compound remaining: 47%
For compound 4 the middle estimate is 8 percentage points above the measured one; measured number inside the range.
By their numbers in this assay, from the lowest: compound 4; then compound 3; then compound 1; then compound 2.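

In this assay, among the compounds shown here, the exchange of one ring for another gives a number 18 percentage points lower from compound 3 to compound 4 (beyond the scatter) and so shows that cyclohexyl in place of cyclopentyl on a saturated chain carbon bound to an amine nitrogen matters at this place, something that no earlier step, all of them starting from an open chain, could show. Set against the open chains, cyclohexyl gives a number 53 percentage points lower from compound 2 to compound 4 (beyond the scatter) and a number 38 percentage points lower from compound 1 to compound 4 (beyond the scatter) and thereby extends the fall in the number as the group grows to all four compounds, with none going against it. Nothing measured here explains this fall.

From the compounds shown here alone, whether the number keeps falling with cycloheptyl remains open. Going by these compounds, it is also open whether a ring holding an oxygen, such as tetrahydropyranyl, or an aromatic phenyl would follow the same order at this place.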